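Working notes: pyridin-4-yl in place of 3-nitrophenyl

This account rests on a few compounds, and the source may have more. Where it says the series, first, only, none or still open, it means among the compounds named here.

compound 1 `COc1cccc(-n2cc(COc3ccc(/C=C4\C[C@]5(C)[C@@H](CC/C=C(\C)CC/C=C(\C)CCC=C(C)C)[C@](C)(O)CC[C@H]5C(C)(C)C4=O)cc3)nn2)c1` value 16600 nM
compound 2 `CC(C)=CCC/C(C)=C/CC/C(C)=C/CC[C@@H]1[C@@]2(C)C/C(=C\c3ccc(OCc4cn(-c5ccccc5C#N)nn4)cc3)C(=O)C(C)(C)[C@@H]2CC[C@@]1(C)O` value 29900 nM
compound 3 `CC(C)=CCC/C(C)=C/CC/C(C)=C/CC[C@@H]1[C@@]2(C)C/C(=C\c3ccc(OCc4cn(-c5cccc([N+](=O)[O-])c5)nn4)cc3)C(=O)C(C)(C)[C@@H]2CC[C@@]1(C)O` value 79400 nM

All three values come from a functional assay on MCF7 cells (Homo sapiens) for cytotoxicity, read by MTT assay, with a stated time of 48 h (a lower number here means a stronger inhibitor, a higher number a weaker inhibitor), and compound 3 at 79400 nM stands highest of them, which makes it the weakest of the three. The next change is pyridin-4-yl in place of 3-nitrophenyl on an aromatic nitrogen and gives compound 4 `CC(C)=CCC/C(C)=C/CC/C(C)=C/CC[C@@H]1[C@@]2(C)C/C(=C\c3ccc(OCc4cn(-c5ccncc5)nn4)cc3)C(=O)C(C)(C)[C@@H]2CC[C@@]1(C)O` with pyridin-4-yl in place of 3-nitrophenyl on an aromatic nitrogen.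

The measured steps that bear on this all change the group on that same aromatic nitrogen. Two of them end at compound 3: a 4.8-fold higher number from compound 1 to compound 3 (0.68 log units; beyond the scatter) and a 2.7-fold higher number from compound 2 to compound 3 (0.42 log units; beyond the scatter) are both modest in size. The remaining step of a 1.8-fold higher number from compound 1 to compound 2 (0.26 log units; within the scatter) stays within the scatter. For the measured compounds named here, no measured compound carries pyridin-4-yl, so these steps show the size of change seen at this place and no direction specific to the new group. With compound 3 at 79400 nM and the other two at lower numbers, a move toward a lower number in this assay is expected on leaving 3-nitrophenyl. The estimate means a 2.3-fold lower number from compound 3 to compound 4 (0.36 log units; beyond the scatter) as an expected step of modest size. Compound 4 is expected at 35000 nM with an estimated range from 12000 nM to 100000 nM as the likely span.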

Compound 4, half-maximal inhibitory concentration: 37500 nM
The estimate for compound 4 lay 1.1-fold (0.03 log units) below the measured number; low and high end bracket the measured number.
By their numbers in this assay, from the lowest: compounds 1, 2 and 4 (each within the scatter of the next, the first and the last beyond it); then compound 3.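

In this assay, pyridin-4-yl brings the first ring with a hetero atom onto the aromatic nitrogen of the five-membered ring, and the series keeps its measurable activity with this smaller group, which has fewer heavy atoms than 3-nitrophenyl: the reading is a 2.1-fold lower number from compound 3 to compound 4 (0.33 log units; beyond the scatter). For the compounds shown here, this leaves 3-nitrophenyl as the only group at this place with a number beyond the scatter of all the others, although the new ring brings no gain over the best of the aryl groups: a 2.3-fold higher number from compound 1 to compound 4 (0.35 log units; beyond the scatter), while the comparison with 2-cyanophenyl gives a 1.3-fold higher number from compound 2 to compound 4 (0.10 log units; within the scatter), so those two groups cannot be told apart here. All steps at this place remain modest or within the scatter, and no supporting measurement is available to account for any of them.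

The compounds shown leave open whether the place of the ring nitrogen matters, as pyridin-2-yl and pyridin-3-yl would test. They also leave open how a non-aromatic group on that nitrogen, such as a piperidine ring or a short chain ending in a carboxylic acid, would read against these aryl groups.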